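The source may report more compounds than this note shows. Statements on the series, on what has been measured and on what is new or still open speak of the compounds shown alone.

Compound 1 `O=C(O)c1cc(-c2cccc(COc3ccc4c(=O)n(C5CC5)sc4c3)c2)ccc1Cl` sits at the top of what has been measured so far. In an ADME assay on a cell-free system (plasma, Rattus norvegicus) for metabolic stability, read by LC-MS, with a stated time of 1 h, at 37 degrees C, tested at 100 uM (a higher number here means that more of the compound is left, a lower number that less of the compound is left), compound 1 gives 100%. Two other compounds share the same shared core and the same read-out: compound 2 `Cc1ccc(C(=O)O)cc1-c1cccc(COc2ccc3c(c2)CN(C2CCCC2)C3=O)c1` gives 100% in this assay, and compound 3 `O=C(O)c1cc(-c2cccc(COc3ccc4c(=O)n(C5CCCC5)sc4c3)c2)ccc1F` gives 100%. Compound 1 is level with both at the digits shown, nearest to compound 2 and furthest from compound 3, though neither gap reaches beyond the scatter. Among the compounds with values here, no pair of these measured compounds differs in a single place, so no measured step is available to guide the next change.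

Compound 4 `CC(C)CCn1sc2cc(OCc3cccc(-c4ccc(Cl)c(C(=O)O)c4)c3)ccc2c1=O` has not yet been run. Its difference from compound 1 is isopentyl in place of cyclopropyl on an aromatic nitrogen on the aromatic nitrogen of the five-membered ring of the shared core. With all three measured compounds fully intact in this assay, the account expects the step from compound 1 to compound 4 to be none beyond the scatter, or at most a small loss, a number 5 percentage points lower from compound 1 to compound 4 (within the scatter). For compound 4 the expected value is 95%, estimated to lie between 80% and 100%.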

Compound 4, percent of the compound remaining: 91%
Estimate against measurement, compound 4: 4 percentage points above; the measured number falls inside the stated range.
By their numbers in this assay, from the lowest: compounds 4, 1, 2 and 3 (each within the scatter of the next).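

Within the data shown here, this is the first step that can be read at a single place. In this assay, isopentyl in place of cyclopropyl on an aromatic nitrogen gives a number 9 percentage points lower from compound 1 to compound 4 (within the scatter), so at this position an open chain with no ring stands in for a three-membered ring without a step beyond the scatter. Nothing measured here offers an explanation for the size of this step.

The compounds shown leave open whether a chain ending in an amine or a hydroxyl group on this same nitrogen would also stay within the scatter of compound 1 in this assay. Among these compounds, they also leave open how this read-out responds to a single change anywhere else on the shared core, as this remains the only such step.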